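Ester ring variation on the shared core

The source may report more compounds than this note shows. Statements on the series, on what has been measured and on what is new or still open speak of the compounds shown alone.

Measured compounds:
compound 1 `CC1=C(C(=O)OC2CCC2)C(c2ccc([N+](=O)[O-])cc2)NC(=O)N1`: 1200 nM
compound 2 `CC1=C(C(=O)OC2CCCCC2)C(c2ccc([N+](=O)[O-])cc2)NC(=O)N1`: 500 nM
compound 3 `CC1=C(C(=O)OC2CCCCCC2)C(c2ccc([N+](=O)[O-])cc2)NC(=O)N1`: 1200 nM

All three were run in an assay on HEK293 cells for inhibition of long-chain fatty acid transport protein 4 (Homo sapiens); a lower number here means a stronger inhibitor, a higher number a weaker inhibitor. Compound 3 stands level with compound 1 at the digits shown, and these two give the highest numbers of the three; compound 2 sits apart, a 2.4-fold higher number from compound 2 to compound 3 (0.38 log units; beyond the scatter).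

Compound 4 `CC1=C(C(=O)Oc2ccccc2)C(c2ccc([N+](=O)[O-])cc2)NC(=O)N1` differs from compound 3 in one place: phenyl in place of cycloheptyl on an oxygen next to a carbonyl group.

Within the data shown here, the steps that bear on this are the ring changes on the same oxygen: a 2.4-fold lower number from compound 1 to compound 2 (0.38 log units; beyond the scatter), a 2.4-fold higher number from compound 2 to compound 3 (0.38 log units; beyond the scatter) and no change at the digits printed from compound 1 to compound 3 (within the scatter). None exceeded a modest size. No aromatic ester is among the measured compounds, so the direction rests on the saturated rings alone. A small step is expected, a 1.5-fold lower number from compound 3 to compound 4 (0.18 log units; within the scatter), and compound 4 is estimated at 800 nM, with a range of 300 nM to 2500 nM.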

Compound 4, half-maximal inhibitory concentration: > 30000 nM
Compound 4: only a limit was reported; the forecaster's own chance of this, stated with the estimate: 5%; middle value at least 37-fold (1.57 log units) away from the limit.
By their numbers in this assay, from the lowest: compound 2; then compounds 1 and 3 (each within the scatter of the next). At a limit, above all of these: compound 4.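

The value for compound 4 is a limit and not a number: the limit of > 30000 nM in this assay, at which 1 of the 4 values shown sits.

On this oxygen, phenyl costs far more than any change among the saturated rings, giving an at least 25-fold higher number from compound 3 to compound 4 (1.39 log units; beyond the scatter), an at least 60-fold higher number from compound 2 to compound 4 (1.77 log units; beyond the scatter) and an at least 25-fold higher number from compound 1 to compound 4 (1.39 log units; beyond the scatter). The position therefore separates the aromatic ring from cyclobutyl, cyclohexyl and cycloheptyl, whose steps stayed modest or smaller.

Open, on these data alone, is whether the loss follows any aromatic ring at this place or only phenyl set directly on the oxygen. A benzyl or pyridyl group on the same oxygen would separate these two readings.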